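A double bond in the long amide chain

The compounds below may be only part of what the source reports. "The series", "measured", "known", "first", "only" and "open" are said of these compounds alone.

In a functional assay on cells (Homo sapiens) for antiproliferative activity, read by sulforhodamine B assay, with a stated time of 48 h (a lower number here means a stronger inhibitor, a higher number a weaker inhibitor), compound 1 (`CCCCCCCCCCCCNC(=O)[C@@H]1CSC(c2ccc(NC(C)=O)cc2)N1`) gives a value of 2400 nM. Compound 2 (`CCCCCCCCCCCCCCCCCCNC(=O)[C@@H]1CSC(c2ccc(NC(C)=O)cc2)N1`) stands at 22300 nM, the higher of the two numbers and so the weaker inhibitor. Compound 3 (`CCCCCCCCC/C=C\CCCCCCCNC(=O)[C@@H]1CSC(c2ccc(NC(C)=O)cc2)N1`) keeps the shared core and differs from compound 2 only in its chain (a group of 11 heavy atoms (11 carbon; no ring) in place of a group of 11 heavy atoms (11 carbon; no ring), on a saturated chain carbon, seven bonds along the chain from an amide-type nitrogen). For the measured compounds named here, only one measured step bears on this change (a 9.3-fold higher number from compound 1 to compound 2 (0.97 log units; beyond the scatter)). That step is modest and beyond the scatter, but it alters chain length, whereas here the group that leaves and the group that enters hold the same number of carbons. Going by the values given here, no measured pair tests a double bond. A smaller step than that one is therefore expected in this assay, tentatively toward a lower number (a 2.5-fold lower number from compound 2 to compound 3 (0.39 log units; beyond the scatter)). Compound 3 is estimated at about 9000 nM, with an expected range of 3000 nM to 25000 nM in this assay.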

Compound 3, half-maximal inhibitory concentration: 1400 nM
Compound 3: the middle estimate sits 6.4-fold (0.81 log units) above what was measured; measured number below the stated range.
By their numbers in this assay, from the lowest: compounds 3 and 1 (each within the scatter of the next); then compound 2.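

In this assay, the double bond seven bonds along the chain from an amide-type nitrogen brings a 16-fold lower number from compound 2 to compound 3 (1.20 log units; beyond the scatter), a large step even though undecyl and the group that replaces it each hold 11 carbon. Chain size alone therefore does not set the number among these compounds, for the longer unsaturated chain gives a 1.7-fold lower number from compound 1 to compound 3 (0.23 log units; within the scatter), while the saturated chain of compound 2 remains weaker. No measurement shown accounts for this difference.

The compounds shown leave open whether a trans double bond, a triple bond or a shorter chain carrying a double bond would give the same result. Also open, from the compounds shown here alone, is whether a chain with two double bonds would follow compound 3.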